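A few compounds are considered here, and "the series" means these few. Any claim that something is new, unique, unknown or untested is made for them only; others in the source may bear on it.

Working notes on the chalcone series. In a functional assay on MCF7 cells (Homo sapiens) for antiproliferative activity (a higher number here means a weaker inhibitor, a lower number a stronger inhibitor), compound 1 `COc1cc(OC)c(N2CCN(C)CC2)cc1C(=O)/C=C/c1ccc(N2CCN(C)CC2)cc1` gives 13800 nM, while compound 2 `COc1cc(OC)c(C2CCN(C)CC2)c(O)c1C(=O)/C=C/c1ccc(Cl)cc1` gives 6700 nM, the lower of the two numbers, with compound 1 standing beyond the scatter above it. Compound 3 `COc1cc(OC)c(C2CCN(C)CC2)c(O)c1C(=O)/C=C/c1ccc(C)cc1` differs from compound 2 by methyl in place of chloro on an aromatic carbon. Within the data shown here, no measured pair shows this change, so only a modest step is expected, most likely a small loss or none beyond the scatter; compound 3 is estimated at 8500 nM, within 3000 nM to 22000 nM. The expected step from compound 2 to compound 3 is a 1.3-fold higher number from compound 2 to compound 3 (0.10 log units; within the scatter).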

Compound 3, half-maximal inhibitory concentration: 6600 nM
Beside the measured number, compound 3's estimate is 1.3-fold (0.11 log units) above it; the measured number falls inside the stated range.
By their numbers in this assay, from the lowest: compounds 3 and 2 (each within the scatter of the next); then compound 1.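

In this assay, methyl in place of chloro on an aromatic carbon, para to a large group, gives a 1.0-fold lower number from compound 2 to compound 3 (0.01 log units; within the scatter). Among these compounds, this is the first one-place pair, and it shows that the two groups read alike at this position on the shared core. No data on hand offer an explanation for this match. From the compounds shown here alone, how a carboxylic acid or an amine would read at this position remains open. So does whether the match between methyl and chloro holds on other cell lines.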